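This account rests on a few compounds, and the source may have more. Where it says the series, first, only, none or still open, it means among the compounds named here.

- Compound 1 `O=C1Nc2c(C(F)(F)F)cccc2C1(c1ccc(OC(F)(F)F)cc1)c1ccc(O)c(F)c1`: 33 nM
- Compound 2 `Cc1cc(C2(c3ccc(OC(F)(F)F)cc3)C(=O)Nc3c(C(F)(F)F)cccc32)ccc1O`: > 1000 nM

In a functional assay on MCF7 cells (Homo sapiens) for inhibition, read by resazurin assay, with a stated time of 24 h (on this read-out lower numbers stand for stronger inhibition and higher numbers for weaker inhibition), compound 1 gives 33 nM. Compound 2 stands at > 1000 nM, which is a limit of the assay and not a number.

Compound 3 `Cc1cc(C2(c3ccc(OC(F)(F)F)cc3)C(=O)Nc3c(C(F)(F)F)cccc32)cc(C)c1O` is the next structure to be tested. It differs from compound 2 by methyl in place of hydrogen on an aromatic carbon, ortho to a hydroxy group and meta to a methyl group, turning 4-hydroxy-3-methylphenyl into 4-hydroxy-3,5-dimethylphenyl.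

For the measured compounds named here, only one measured step bears on this change: an at least 30-fold higher number from compound 1 to compound 2 (1.48 log units; beyond the scatter). It is large and beyond the scatter, and it put methyl in place of fluoro on an aromatic carbon. Going by the values given here, it is an imperfect guide, since the new methyl replaces hydrogen rather than fluoro, but it is the only evidence on methyl in this ring. A move toward a higher number is therefore expected in this assay, of uncertain size, and the result may again be only a limit.

The expected change is a step that the limit leaves unreadable from compound 2 to compound 3. Compound 3 is estimated at 2000 nM, with an expected range of 400 nM to 10000 nM.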

Compound 3, half-maximal inhibitory concentration: > 1000 nM
Compound 3 was reported as a limit; the forecaster's own chance of this, stated with the estimate: 70%; the middle value does not contradict the limit.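

Compound 3 reads > 1000 nM in this assay, again a limit of the assay and not a number. A methyl added to the 4-hydroxy-3-methylphenyl group, ortho to the hydroxy group, therefore does not bring the read-out back into the measurable range, and the 4-hydroxy-3,5-dimethylphenyl group in place of 3-fluoro-4-hydroxyphenyl gives an at least 30-fold higher number from compound 1 to compound 3 (1.48 log units; beyond the scatter), so a second methyl-bearing compound now stands well apart from the fluoro compound. The step between the two methyl compounds cannot be read, as both end at the same limit: the limit of > 1000 nM in this assay, at which 2 of the 3 values shown sit.

The compounds shown cannot say whether the added methyl weakens inhibition further or changes nothing, since any difference between compound 2 and compound 3 lies out of reach of this read-out. Also open is whether another group on this aromatic carbon, such as chloro, methoxy or an amine, would keep inhibition near that of compound 1, or whether fluoro is the only group shown here that gives a measurable value.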